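Cyclopentyl ureas: aryl swap from compound 1 to compound 4

This account rests on a few compounds, and the source may have more. Where it says the series, first, only, none or still open, it means among the compounds named here.

Measured so far:
compound 1 `Cc1ccccc1C1(CNC(=O)Nc2c(C(C)C)cccc2C(C)C)CCCC1` — 17 nM
compound 2 `CC(C)c1cccc(C(C)C)c1NC(=O)NCC1(c2ccc(Cl)cc2)CCCC1` — 32 nM
compound 3 `CC(C)c1cccc(C(C)C)c1NC(=O)NCC1(c2ccc([N+](=O)[O-])cc2)CCCC1` — 131 nM

In an assay on microsomes for inhibition of acyl-CoA:cholesterol acyltransferase (Oryctolagus cuniculus) (a lower number here means a stronger inhibitor, a higher number a weaker inhibitor), compound 1 gives the lowest of the three numbers; compound 2 lies within the scatter of it, compound 3 beyond it. Compound 4 `CC(C)c1cccc(C(C)C)c1NC(=O)NCC1(c2ccc(NCCO)cc2)CCCC1` differs from compound 1 by 4-((2-hydroxyethyl)amino)phenyl in place of 2-methylphenyl on a saturated ring carbon. Among the measured compounds shown here, the steps that bear on this are the earlier swaps at the same saturated ring carbon: a 1.9-fold higher number from compound 1 to compound 2 (0.27 log units; within the scatter) and a 7.7-fold higher number from compound 1 to compound 3 (0.89 log units; beyond the scatter); the exchange of the group on the aromatic carbon gave a 4.1-fold higher number from compound 2 to compound 3 (0.61 log units; beyond the scatter). Both replacements of 2-methylphenyl raised the number, so a weakening step is expected for compound 4, comparable to the nitro case or somewhat larger: an 8.8-fold higher number from compound 1 to compound 4 (0.95 log units; beyond the scatter). The estimate for compound 4 is 150 nM, with a range from 40 nM to 600 nM.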

Compound 4, half-maximal inhibitory concentration: 25 nM
Compound 4: the middle estimate sits 6.0-fold (0.78 log units) above what was measured, and the stated range ends above it.
By their numbers in this assay, from the lowest: compounds 1, 4 and 2 (each within the scatter of the next); then compound 3.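

In this assay the 4-((2-hydroxyethyl)amino)phenyl group on the saturated ring carbon is not separated from the earlier aryl groups of compound 1 and compound 2 (a 1.5-fold higher number from compound 1 to compound 4 (0.17 log units; within the scatter); a 1.3-fold lower number from compound 2 to compound 4 (0.11 log units; within the scatter)). The nitro group of compound 3 therefore does not show a general cost of replacing 2-methylphenyl, since (2-hydroxyethyl)amino in its place gives a clear step (a 5.2-fold lower number from compound 3 to compound 4 (0.72 log units; beyond the scatter)). Nothing available here explains this result. Open, from the compounds shown here alone, is whether the hydroxyl matters, or whether a plain amine, a carboxylic acid or a longer chain on the same aromatic carbon would behave alike.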